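From 4-methylphenyl to 4-ethylphenyl: working notes

A few compounds are considered here, and "the series" means these few. Any claim that something is new, unique, unknown or untested is made for them only; others in the source may bear on it.

In a functional assay on PC-3 cells (Homo sapiens) for cytotoxicity (on this read-out higher numbers stand for an effect only at larger amounts of compound and lower numbers for an effect already at smaller amounts), compound 1 `COC1=C(C)C(=O)/C(=C(O)/C=C/c2ccc(OC)cc2)C(=O)C1(C)C` gives 18.2 ug/mL as its value. Compound 2 `COC1=C(C)C(=O)/C(=C(O)/C=C/c2ccc(O)cc2)C(=O)C1(C)C` gives > 20 ug/mL and this is a limit of the assay. Compound 3 `COC1=C(C)C(=O)/C(=C(O)/C=C/c2ccc(C)cc2)C(=O)C1(C)C` gives 8.2 ug/mL and holds the lower of the two measured numbers. Compound 4 `CCc1ccc(/C=C/C(O)=C2/C(=O)C(C)=C(OC)C(C)(C)C2=O)cc1` follows with methyl in place of hydrogen on a saturated chain carbon bound to an aromatic carbon as its difference, methyl in place of hydrogen on a saturated chain carbon bound to an aromatic carbon. The closest measured steps are a 2.2-fold lower number from compound 1 to compound 3 (0.35 log units; beyond the scatter) and an at least 2.4-fold lower number from compound 2 to compound 3 (0.38 log units; beyond the scatter) in size, both modest at the least, and both swap the group that is extended here. For the measured compounds named here, no measured step lengthens a chain, so no shift beyond the scatter is expected in this assay here. The expected step is a 1.1-fold lower number from compound 3 to compound 4 (0.04 log units; within the scatter) on this estimate. Compound 4 is estimated at 7.5 ug/mL with an expected range of 3.5 ug/mL to 16 ug/mL for the measurement.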

Compound 4, concentration for half-maximal effect: 15.1 ug/mL
Estimate against measurement, compound 4: 2.0-fold (0.30 log units) below; measured number inside the range.
By their numbers in this assay, from the lowest: compounds 3, 4 and 1 (each within the scatter of the next, the first and the last beyond it). At a limit, above all of these: compound 2.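

Extending methyl to ethyl on the saturated chain carbon bound to an aromatic carbon gives the first chain-lengthening step in this assay, a 1.8-fold higher number from compound 3 to compound 4 (0.27 log units; within the scatter). Replacing the methoxy group with ethyl gives a 1.2-fold lower number from compound 1 to compound 4 (0.08 log units; within the scatter), so compound 4 stays within the scatter of both compound 3 and compound 1, even though those two differ beyond it. Ethyl in place of hydroxy reads only as a floor against a limit of the assay, an at least 1.3-fold lower number from compound 2 to compound 4 (0.12 log units; that floor lies within the scatter), and that limit is: the limit of > 20 ug/mL in this assay, at which 1 of the 4 values shown sits.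

As far as these compounds go, whether a propyl chain, an amine or a carboxylic acid at this place would move the number beyond the scatter remains open.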